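This account rests on a few compounds, and the source may have more. Where it says the series, first, only, none or still open, it means among the compounds named here.

Measured compounds:
compound 2, `O=CCN1N=C(c2ccc3ccccc3c2)CC1c1ccccc1[N+](=O)[O-]` — in a functional assay on PC-3 cells (Homo sapiens) for cytotoxicity, read by sulforhodamine B assay, with a stated time of 48 h (on this read-out lower numbers stand for stronger inhibition and higher numbers for weaker inhibition), compound 2 gives 3010 nM
compound 1, `COc1cc(OC)c(C2CC(c3ccco3)=NN2C(C)=O)cc1OC` — in this assay compound 1 gives 8980 nM

Only these two numbers are in hand. Compound 2 has the lower of them; the nearest, compound 1, sits higher by a margin that lies beyond the usual scatter of this kind of measurement. The two compounds differ at several places at once, so their gap cannot be tied to any single change.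

Compound 3, `COc1ccc(C2CC(c3ccc4ccccc4c3)=NN2CC=O)cc1O`, is not yet measured. It keeps the core of compound 2, including the naphthalenyl group and the formylmethyl group, and differs in one place: 3-hydroxy-4-methoxyphenyl in place of 2-nitrophenyl on a saturated ring carbon. Within the data shown here, no measured pair in this set isolates that exchange, so the size and direction of the step have no direct precedent. With compound 2 at 3010 nM as the only anchor, the change is expected to shift the number by less than the gap between the two measured compounds, with the direction uncertain. Compound 3 is therefore expected to give about 4500 nM, within a range from 1500 nM to 14000 nM. The step implied by this estimate, a 1.5-fold higher number from compound 2 to compound 3 (0.17 log units; within the scatter), is expected to be a small one.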

Compound 3, half-maximal inhibitory concentration: 2040 nM
Beside the measured number, compound 3's estimate is 2.2-fold (0.34 log units) above it, and the stated range covers the measured number.
By their numbers in this assay, from the lowest: compounds 3 and 2 (each within the scatter of the next); then compound 1.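

In this assay, among these compounds, the exchange of 2-nitrophenyl for 3-hydroxy-4-methoxyphenyl on the saturated ring carbon gives a 1.5-fold lower number from compound 2 to compound 3 (0.17 log units; within the scatter) and is the first step in this set that isolates a single place. It shows that this position, next to the ring nitrogen, can carry either of these two substituted phenyl groups with no difference beyond the scatter, even though a nitro group leaves and a hydroxy and a methoxy group enter. No measured evidence bears on this result, so nothing can be said about what lies behind it.

The compounds shown do not separate the hydroxy group from the methoxy group, so the share of each in this result remains open, as does the outcome with unsubstituted phenyl or with an aminophenyl or carboxyphenyl group at this position. They also leave open whether an acetyl group in place of the formylmethyl group, or a furan ring in place of the naphthalenyl group, would change the number on this same core.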